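The source may report more compounds than this note shows. Statements on the series, on what has been measured and on what is new or still open speak of the compounds shown alone.

Compound 3 `Cc1c(C2CC2)nc2ccc(-n3ccc(OCc4ccc(C(F)(F)F)cc4)cc3=O)cn12` sits second highest among the three numbers obtained in an assay on CHO cells for displacement of a labelled ligand from melanin-concentrating hormone receptor 1 (Homo sapiens), read by scintillation counting, with a stated time of 1 h; a lower number here means a stronger inhibitor, a higher number a weaker inhibitor: compound 3 gives 72 nM, its nearest neighbour compound 1 `Cc1c(C2CC2)nc2ccc(-n3ccc(OCc4ccc(F)cc4)cc3=O)cn12` gives 47 nM, and the step of a 1.5-fold higher number from compound 1 to compound 3 (0.19 log units; within the scatter) stays within the scatter, while compound 2 `Cc1c(C2CC2)nc2ccc(-n3ccc(OCc4ccc(C(C)C)cc4)cc3=O)cn12` gives 410 nM and the step of a 5.7-fold lower number from compound 2 to compound 3 (0.76 log units; beyond the scatter) lies beyond it. Compound 4 `Cc1c(C2CC2)nc2ccc(-n3ccc(OCc4ccccn4)cc3=O)cn12` differs from compound 3 by pyridin-2-yl in place of 4-(trifluoromethyl)phenyl on a saturated chain carbon bound to an oxygen on an aromatic ring. Within the data shown here, none of the measured steps covers this change: the steps of an 8.7-fold higher number from compound 1 to compound 2 (0.94 log units; beyond the scatter) and a 5.7-fold lower number from compound 2 to compound 3 (0.76 log units; beyond the scatter) swap one substituent for another on the same carbon ring, and the step of a 1.5-fold higher number from compound 1 to compound 3 (0.19 log units; within the scatter) does likewise, whereas the change to compound 4 replaces the whole ring. Among the measured compounds shown here, the only guidance is that the ring substituent can shift this assay by modest amounts in either direction. Compound 4 is therefore expected to show a modest rise in this assay, a 2.1-fold higher number from compound 3 to compound 4 (0.32 log units; beyond the scatter), with a wide spread, and its estimated value is 150 nM, between 40 nM and 600 nM.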

Compound 4, half-maximal inhibitory concentration: 240 nM
For compound 4 the middle estimate is 1.6-fold (0.20 log units) below the measured one, within the range that was stated.
By their numbers in this assay, from the lowest: compounds 1 and 3 (each within the scatter of the next); then compounds 4 and 2 (each within the scatter of the next).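

In this assay, the whole ring at this position can be exchanged without abolishing the read-out, but pyridin-2-yl does not match the two best benzyl-type groups: a 3.3-fold higher number from compound 3 to compound 4 (0.52 log units; beyond the scatter) and a 5.1-fold higher number from compound 1 to compound 4 (0.71 log units; beyond the scatter). Against the 4-isopropylphenyl group the picture differs, as a 1.7-fold lower number from compound 2 to compound 4 (0.23 log units; within the scatter) leaves these two compounds indistinguishable, so a ring nitrogen with no further substituent reaches the same level as the poorest substituted ring shown. Nothing shown here gives a reason for these steps.

Compound 4 changes the ring atom and removes the ring substituent in one step, so the two contributions cannot be separated. A plain phenyl ring, or a pyridine ring bearing fluoro or trifluoromethyl, would be needed to tell them apart.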